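The source may hold more compounds than are shown below. What is called first, only, known or untested is meant among the compounds shown, and "the series" means these compounds.

Of the compounds shown here, two have been measured so far in a functional assay on C6 cells (Rattus norvegicus) for cytotoxicity, read by MTT assay, with a stated time of 24 h, tested at 6 ug/mL; on this read-out higher numbers stand for a weaker effect at the one concentration tested and lower numbers for a stronger effect. Compound 1 `Cc1nnc(SCC(=O)N/N=c2/scc(-c3ccc(F)cc3)n2-c2ccccc2)s1` gives 74.3% in this assay. Compound 2 `O=C(CSc1nnnn1-c1ccccc1)N/N=c1/scc(-c2ccc(F)cc2)n1-c1ccccc1` gives 74.9% in this assay. The one measured step, a number 0.6 percentage points higher from compound 1 to compound 2 (within the scatter), exchanges one sulfur-bound heterocycle for another, and its two numbers sit together within the scatter, so on the numbers shown compound 2 stands alongside compound 1 rather than apart from it.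

Compound 3 `N#Cc1ccc(-c2cs/c(=N/NC(=O)CSc3nnnn3-c3ccccc3)n2-c2ccccc2)cc1` has not yet been measured. It differs from compound 2 in one place: cyano in place of fluoro on an aromatic carbon. Among the compounds with values here, the change sits on the six-membered aromatic ring of carbon only, a part of the molecule that no measured step touches; the single measured step altered a different region and so gives no direct guide to what cyano in place of fluoro will do. With nothing in the data pointing either way, no step beyond the scatter is expected. Compound 3 is therefore expected to give about 73% in this assay, with a likely range from 58% to 88%, which means an expected step of a number 1.9 percentage points lower from compound 2 to compound 3 (within the scatter).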

Compound 3, a percentage reported as activity, at one concentration (the size of the read-out at that concentration, not a potency): 78.8%
The estimate for compound 3 lay 5.8 percentage points below the measured number; low and high end bracket the measured number.
By their numbers in this assay, from the lowest: compounds 1, 2 and 3 (each within the scatter of the next).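

In this assay, the exchange of 4-fluorophenyl for 4-cyanophenyl gives a number 3.9 percentage points higher from compound 2 to compound 3 (within the scatter), so this read-out does not separate the two groups. Within the data shown here, this is the first view of the six-membered aromatic ring of carbon only, and it shows that the position para to a large group can carry a cyano group, with its triple bond and hydrogen-bond acceptor, without a step beyond the scatter. Nothing further is available to explain why the two groups read alike here.

The compounds shown leave open whether a group of a different kind at this same place, such as an amine, a carboxylic acid or a longer chain like butyl, would give a step beyond the scatter. They also leave open whether 5-methyl-1,3,4-thiadiazol-2-yl and 1-phenyl-1H-tetrazol-5-yl on the sulfur would still read alike with 4-cyanophenyl in the molecule, and the single tested concentration says nothing about potency.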